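Adding chloro to compound 3: working notes

The source may report more compounds than this note shows. Statements on the series, on what has been measured and on what is new or still open speak of the compounds shown alone.

Measured so far in a functional assay on MCF7 cells (Homo sapiens) for cytotoxicity, read by MTT assay, with a stated time of 72 h; on this read-out lower numbers stand for stronger inhibition and higher numbers for weaker inhibition:

compound 1 `COc1ccc(/C=C2\CCC/C(=C\c3ccc(Cl)cc3)C2=O)cc1OC` gives 6300 nM
compound 2 `COc1cccc(/C=C2\CCC/C(=C\c3ccc(OC)c(OC)c3)C2=O)c1` gives 4600 nM
compound 3 `COc1ccc(/C=C2\CCC/C(=C\c3ccc(O)cc3)C2=O)cc1OC` gives 17000 nM

Compound 3 has the highest number of the three, and both of its steps lie beyond the scatter: a 2.7-fold higher number from compound 1 to compound 3 (0.43 log units; beyond the scatter) and a 3.7-fold higher number from compound 2 to compound 3 (0.57 log units; beyond the scatter) in this assay. Compound 4 `COc1ccc(/C=C2\CCC/C(=C\c3ccc(O)c(Cl)c3)C2=O)cc1OC` differs from compound 3 by one change, (chloro in place of hydrogen on an aromatic carbon), which takes 4-hydroxyphenyl to 3-chloro-4-hydroxyphenyl. Among the compounds with values here, no measured compound carries chloro and hydroxy together on one ring, so the evidence is indirect. The closest measured step is a 2.7-fold higher number from compound 1 to compound 3 (0.43 log units; beyond the scatter), where hydroxy stands in place of chloro on an aromatic carbon. Compound 4 keeps the hydroxy, so that step can only be read loosely and in reverse. The step of a 1.4-fold lower number from compound 1 to compound 2 (0.14 log units; within the scatter) adds little. A modest move towards a lower number is expected, with a real chance of none beyond the scatter. The expected change is a 2.1-fold lower number from compound 3 to compound 4 (0.33 log units; beyond the scatter) here. For compound 4 the estimated value is 8000 nM in this assay, with an expected range from 3500 nM to 18000 nM as its limits.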

Compound 4, half-maximal inhibitory concentration: 12300 nM
Beside the measured number, compound 4's estimate is 1.5-fold (0.19 log units) below it; low and high end bracket the measured number.
By their numbers in this assay, from the lowest: compounds 2, 1, 4 and 3 (each within the scatter of the next, the first and the last beyond it).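

Chloro in place of hydrogen on the aromatic carbon ortho to the hydroxy group produces no step beyond the scatter in this assay (a 1.4-fold lower number from compound 3 to compound 4 (0.14 log units; within the scatter)), so this position has not yet shown a clear response to this change. The 3-chloro-4-hydroxyphenyl ring lies within the scatter of the 4-chlorophenyl ring (a 2.0-fold higher number from compound 1 to compound 4 (0.29 log units; within the scatter)), while compound 3 lay beyond it, yet it remains beyond the scatter of the 3-methoxyphenyl ring (a 2.7-fold higher number from compound 2 to compound 4 (0.43 log units; beyond the scatter)). No evidence bears on a cause for these results.

Still open, on these data alone, is whether an amine or a carboxylic acid at this position would give a step beyond the scatter from compound 3. Also open, as far as these compounds go, is whether chloro at this position would behave the same way with an amine in place of the hydroxy group.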